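Chloro-aryl variant on the aromatic nitrogen: compound 3

This account rests on a few compounds, and the source may have more. Where it says the series, first, only, none or still open, it means among the compounds named here.

Within the data shown here, compound 2 `COc1cc2c(Oc3ccc(NC(=O)c4nn(-c5ccccc5OC(F)(F)F)c(=O)cc4C)cc3F)ccnc2cc1OCCCN1CCN(C)CC1` stands at 100 nM in a functional assay on MKN-45 cells (Homo sapiens) for inhibition, read by MTT assay, with a stated time of 72 h (on this read-out higher numbers stand for weaker inhibition and lower numbers for stronger inhibition), one of only two numbers so far; compound 1 `COc1cc2c(Oc3ccc(NC(=O)c4nn(-c5ccccc5OC(F)(F)F)c(=O)cc4C)cc3F)ccnc2cc1OCCCN1CCC(C)CC1` gives 70 nM, and the two lie within the scatter of each other, as the step of a 1.4-fold higher number from compound 1 to compound 2 (0.15 log units; within the scatter) shows. That step concerns the saturated amine ring at the end of the chain, not the aryl group on the aromatic nitrogen.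

Compound 3 `COc1cc2c(Oc3ccc(NC(=O)c4nn(-c5ccc(Cl)cc5)c(=O)cc4C)cc3F)ccnc2cc1OCCCN1CCN(C)CC1` differs from compound 2 in one place: 4-chlorophenyl in place of 2-(trifluoromethoxy)phenyl on an aromatic nitrogen. Among the measured compounds shown here, no measured pair changes this aryl group, so there is nothing to calibrate the step against; the one known step sits elsewhere and bears on it only as a sign that a single peripheral change has so far stayed within the scatter. The expected step from compound 2 to compound 3 in this assay is therefore none beyond the scatter, with a wide range for the lack of precedent: no change at the digits printed from compound 2 to compound 3 (within the scatter). Compound 3 is estimated at 100 nM, within 30 nM to 400 nM.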

Compound 3, half-maximal inhibitory concentration: 40 nM
Estimate against measurement, compound 3: 2.5-fold (0.40 log units) above, within the range that was stated.
By their numbers in this assay, from the lowest: compounds 3, 1 and 2 (each within the scatter of the next, the first and the last beyond it).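

Among these compounds, of the single changes, only the one on the aromatic nitrogen moves the number beyond the scatter: in this assay, 4-chlorophenyl in place of 2-(trifluoromethoxy)phenyl gives a 2.5-fold lower number from compound 2 to compound 3 (0.40 log units; beyond the scatter), a modest step, while the amine change at the chain end gives a 1.4-fold higher number from compound 1 to compound 2 (0.15 log units; within the scatter). This position therefore accepts an aryl group with fewer heavy atoms and 0 hydrogen-bond acceptors in place of 2-(trifluoromethoxy)phenyl, with no loss in this read-out. Nothing at hand bears on what lies behind the step.

The substituent and its place on the aryl ring change together, leaving their shares of the step unseparated; 2-chlorophenyl, 4-(trifluoromethoxy)phenyl or unsubstituted phenyl would separate them. On these data alone, whether the step carries over to a 4-methylpiperidin-1-yl chain end also stays open.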